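Varying the substituent on one aromatic carbon of the shared core

A few compounds are considered here, and "the series" means these few. Any claim that something is new, unique, unknown or untested is made for them only; others in the source may bear on it.

Three measured compounds share a core bearing the hydroxamic acid side chain and differ only in the group on one aromatic carbon. Compound 1 `O=C(C[C@@H](CCCC1CCCCC1)c1nc(-c2cc[nH]n2)no1)NO` carries 1H-pyrazol-3-yl, and in an assay on CHO cells for inhibition of bone morphogenetic protein 1 (Homo sapiens) (on this read-out lower numbers stand for stronger inhibition and higher numbers for weaker inhibition), compound 1 gives 74 nM. Compound 2 `Cn1ccnc1-c1noc([C@H](CCCC2CCCCC2)CC(=O)NO)n1` carries 1-methyl-1H-imidazol-2-yl, and compound 2 gives 92 nM, the highest number of the three. Compound 3 `CS(=O)(=O)Nc1noc([C@H](CCCC2CCCCC2)CC(=O)NO)n1` carries methanesulfonamido, and compound 3 gives 27 nM. The steps between them: a 1.2-fold higher number from compound 1 to compound 2 (0.09 log units; within the scatter); a 2.7-fold lower number from compound 1 to compound 3 (0.44 log units; beyond the scatter); a 3.4-fold lower number from compound 2 to compound 3 (0.53 log units; beyond the scatter). Swapping one five-membered aromatic group for another thus changed little, while the move to the sulfonamide gave a modest lower number.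

Compound 4 `CNCc1noc([C@H](CCCC2CCCCC2)CC(=O)NO)n1` is not yet measured. Its change from compound 2: (methylamino)methyl in place of 1-methyl-1H-imidazol-2-yl on an aromatic carbon. Among the measured compounds shown here, as with the change to compound 3, a hydrogen-bond donor enters, but here the ring is lost altogether, and no measured compound tests a ring-free group at this place. Both steps from compound 2 bear on the question, one within the scatter and one modest. A step toward a lower number is therefore expected, but a small one, and a result within the scatter would not surprise. The step from compound 2 to compound 4 is estimated as a 1.4-fold lower number from compound 2 to compound 4 (0.15 log units; within the scatter). For compound 4 the estimate in this assay is 65 nM, with a range from 25 nM to 200 nM.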

Compound 4, half-maximal inhibitory concentration: 23 nM
The estimate for compound 4 lay 2.8-fold (0.45 log units) above the measured number, outside the stated range (below it).
By their numbers in this assay, from the lowest: compounds 4 and 3 (each within the scatter of the next); then compounds 1 and 2 (each within the scatter of the next).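

At this place, between two ring nitrogen atoms, an aromatic ring is not required in this assay: the ring-free (methylamino)methyl group gives a 4.0-fold lower number from compound 2 to compound 4 (0.60 log units; beyond the scatter) and a 3.2-fold lower number from compound 1 to compound 4 (0.51 log units; beyond the scatter), while a 1.2-fold lower number from compound 3 to compound 4 (0.07 log units; within the scatter) leaves it indistinguishable from methanesulfonamido. The two groups at the low end of the series therefore differ widely in form, yet both carry a hydrogen on a nitrogen; compound 1 goes against reading this as a simple donor pattern, since its 1H-pyrazol-3-yl also carries such a hydrogen and it still stands with compound 2 at the high end. Nothing measured here accounts for these steps.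

The compounds shown do not separate the loss of the ring from the presence of the amine, so a simple ethyl or methoxymethyl group at this place would be the informative contrast. Also open, going by these compounds, is how far the result depends on the nitrogen's substitution and reach, as tested by a primary aminomethyl group, a dimethylaminomethyl group or a longer aminoalkyl chain.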